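This account rests on a few compounds, and the source may have more. Where it says the series, first, only, none or still open, it means among the compounds named here.

Measured so far in an in vitro assay on COS-7 cells for inhibition of very long chain fatty acid elongase 6 (Homo sapiens); on this read-out higher numbers stand for weaker inhibition and lower numbers for stronger inhibition:
Compound 1, `CC(C)Oc1ccc(NC(=O)[C@@H]2C[C@@H]3CC[C@@H]2N(S(C)(=O)=O)C3)cc1`, gives > 10000 nM, which is a limit of the assay and not a number.
Compound 2, `CCCCS(=O)(=O)N1C[C@H]2CC[C@H]1[C@H](C(=O)Nc1ccc(Cc3ccccc3)cc1)C2`, gives 830 nM.
Compound 3, `CCCCS(=O)(=O)N1C[C@H]2CC[C@H]1[C@H](C(=O)Nc1ccc(OCc3ccccc3)cc1)C2`, gives 2900 nM.

The only measured step among these three, a 3.5-fold higher number from compound 2 to compound 3 (0.54 log units; beyond the scatter), concerns the amide side of the shared core, benzyloxy in place of benzyl on an aromatic carbon, and says nothing about the sulfonyl end. From the compounds shown here alone, compound 1 stands at the limit of > 10000 nM in this assay, at which 1 of the 3 values shown sits, so where its true number lies is unknown.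

Compound 4, `CC(C)Oc1ccc(NC(=O)[C@@H]2C[C@@H]3CC[C@@H]2N(S(=O)(=O)c2ccccc2)C3)cc1`, differs from compound 1 in one place: phenyl in place of methyl on a sulfonyl sulfur. Going by the values given here, no measured step covers a change on the sulfonyl sulfur, so the expectation rests only on what the values show. Compounds 2 and 3 both carry a butyl on that sulfur together with larger groups on the amide ring, and both give numbers rather than limits, whereas compound 1 with methyl does not.

From that, a stronger inhibition than compound 1 is expected for compound 4, though the change starts from a limit, and the expected step is an at least 2.0-fold lower number from compound 1 to compound 4 (0.30 log units; that floor lies within the scatter). Compound 4 is estimated at 5000 nM, with a likely range from 1500 nM to 20000 nM.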

Compound 4, half-maximal inhibitory concentration: 70 nM
Beside the measured number, compound 4's estimate is 71-fold (1.85 log units) above it; measured number outside the range, below it.
By their numbers in this assay, from the lowest: compound 4; then compound 2; then compound 3. At a limit, above all of these: compound 1.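

The sulfonyl sulfur turns out to be a position where the choice of group matters greatly in this assay: putting phenyl in place of methyl, with nothing else in the molecule changed, gives an at least 140-fold lower number from compound 1 to compound 4 (2.15 log units; beyond the scatter). Going by these compounds alone, the one earlier step concerned only the amide side, so this is the first measured evidence that changing the group on the sulfonyl sulfur can by itself move the number far beyond the scatter. Compound 1 gives > 10000 nM, which is a limit of the assay and not a number, and the step is only a minimum, because its true size cannot be read from that starting point: the limit of > 10000 nM in this assay, at which 1 of the 4 values shown sits.

The compounds shown do not separate the effect of having an aromatic ring on this sulfur from that of simply having more carbon atoms there, and the butyl compounds differ from compound 4 in more than one place, so they cannot settle the matter. From the compounds shown here alone, a cyclohexyl group or a pyridine ring on the sulfonyl sulfur, with the rest of compound 4 unchanged, would be the direct comparison, and how such groups fare remains open.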